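The compounds below may be only part of what the source reports. "The series", "measured", "known", "first", "only" and "open" are said of these compounds alone.

Working notes on the series. For the measured compounds named here, in an assay on isolated protein for binding affinity to 5-hydroxytryptamine receptor 1F (Homo sapiens), read by radioligand binding (a higher number here means a weaker inhibitor, a lower number a stronger inhibitor), compound 1 `CN1CCC(C(=O)c2cccc(NC(=O)c3ccc(F)cc3)c2)CC1` gives 5.1 nM, and compound 2 `COc1c(NC(=O)c2ccc(F)cc2)cccc1C(=O)C1CCN(C)CC1` gives 610 nM, the highest of the two numbers recorded; the single measured step, a 120-fold higher number from compound 1 to compound 2 (2.08 log units; beyond the scatter), is methoxy in place of hydrogen on an aromatic carbon. Compound 3 `CN1CCC(C(=O)c2cccc(NC(=O)c3ccc(F)cc3)c2O)CC1` carries hydrogen in place of methyl on an oxygen on an aromatic ring, so the methyl of that methoxy is removed and a hydroxy remains. Since the methoxy cost the step of a 120-fold higher number from compound 1 to compound 2 (2.08 log units; beyond the scatter), cutting back to hydroxy is expected to recover part of it; a drop of roughly a 6.1-fold lower number from compound 2 to compound 3 (0.79 log units; beyond the scatter) is expected in this assay. Compound 3 is therefore estimated at 100 nM, within 20 nM to 600 nM.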

Compound 3, inhibition constant: 1100 nM
The estimate for compound 3 lay 11-fold (1.04 log units) below the measured number; the measured number lies above the stated range.
By their numbers in this assay, from the lowest: compound 1; then compounds 2 and 3 (each within the scatter of the next).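

The step of a 1.8-fold higher number from compound 2 to compound 3 (0.26 log units; within the scatter) in this assay leaves methoxy and hydroxy indistinguishable, so removing the methyl recovers nothing. The hydroxy also gives a 220-fold higher number from compound 1 to compound 3 (2.33 log units; beyond the scatter) and so, like methoxy, carries a large loss against compound 1. Nothing available explains this loss.

From the compounds shown here alone, whether any substituent at this aromatic carbon is tolerated remains open. A fluorine or a methyl group there, neither linked through oxygen, would show whether the loss follows substitution in general or the oxygen specifically.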